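Notes on the aryl change from compound 2 to compound 3

The compounds below may be only part of what the source reports. "The series", "measured", "known", "first", "only" and "open" are said of these compounds alone.

Measured so far:
compound 1, `COc1cccc(OC)c1OCCNCCOc1ccccc1OCc1cccc([N+](=O)[O-])c1`, 0.0631 nM in an assay on CHO cells for displacement of a labelled ligand from Alpha-1D adrenergic receptor (Homo sapiens); a higher number here means a weaker inhibitor, a lower number a stronger inhibitor
compound 2, `COc1cccc(OC)c1OCCNCCOc1ccccc1OCc1ccc([N+](=O)[O-])cc1`, 0.0501 nM

For the measured compounds named here, compound 2 holds the lowest of the two numbers in this assay; its only neighbour is compound 1, and a 1.3-fold lower number from compound 1 to compound 2 (0.10 log units; within the scatter), so the two are not separable. Compound 3, `COc1ccccc1COc1ccccc1OCCNCCOc1c(OC)cccc1OC`, differs from compound 2 by 2-methoxyphenyl in place of 4-nitrophenyl on a saturated chain carbon bound to an oxygen on an aromatic ring. Going by the values given here, no measured step bears on this change: the single recorded step only relocates the nitro group on its ring rather than replacing it, and lies within the scatter. The expectation for compound 3 is therefore a modest weakening, a 2.6-fold higher number from compound 2 to compound 3 (0.41 log units; beyond the scatter), with wide uncertainty. The estimate for compound 3 in this assay is 0.13 nM, range 0.03 nM to 0.6 nM.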

Compound 3, inhibition constant: 2 nM
Beside the measured number, compound 3's estimate is 15-fold (1.19 log units) below it, outside the stated range (above it).
By their numbers in this assay, from the lowest: compounds 2 and 1 (each within the scatter of the next); then compound 3.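

In this assay the saturated chain carbon bound to an oxygen on an aromatic ring proves sensitive to the aryl group it carries, which relocating the nitro group did not show. Replacing either nitrophenyl with 2-methoxyphenyl gives a large step: a 40-fold higher number from compound 2 to compound 3 (1.60 log units; beyond the scatter) and a 32-fold higher number from compound 1 to compound 3 (1.50 log units; beyond the scatter). No measurement available here accounts for this loss.

The compounds shown leave open whether the loss follows the departure of the nitro group or the arrival of the 2-methoxyphenyl group. A plain phenyl or a 4-methoxyphenyl at this place would separate the two.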